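Swapping carboxy for methyl on a weak channel blocker

The source may report more compounds than this note shows. Statements on the series, on what has been measured and on what is new or still open speak of the compounds shown alone.

Among the compounds with values here, compound 2, `CC1=NC(C)=C(C(=O)O)C(c2cccc(C(=O)O)c2)/C1=C(\O)OC/C=C/c1ccccc1`, gives 37000 nM in a functional assay on IMR-32 cells for inhibition of Voltage-dependent N-type calcium channel subunit alpha-1B (Homo sapiens), read by calcium flux (on this read-out lower numbers stand for stronger inhibition and higher numbers for weaker inhibition), a weak result that sits level with its only measured neighbour. That neighbour, compound 1, `CC1=NC(C)=C(C(=O)O)C(c2ccccc2[N+](=O)[O-])/C1=C(\O)OC/C=C/c1ccccc1`, gives 37000 nM in this assay. The step of no change at the digits printed from compound 1 to compound 2 (within the scatter) shows that replacing one substituent on the aromatic ring held by the saturated ring carbon of the shared core by a quite different one did not move the read-out at all.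

Compound 3, `CC1=NC(C)=C(C(=O)O)C(c2cccc(C)c2)/C1=C(\O)OC/C=C/c1ccccc1`, has not been measured. It differs from compound 2 by methyl in place of carboxy on an aromatic carbon. Within the data shown here, the single measured step that bears on this position is no change at the digits printed from compound 1 to compound 2 (within the scatter), and it was flat, so the ring substituent appears to have little say over the read-out here, within the two compounds seen. The expected step of a 1.1-fold lower number from compound 2 to compound 3 (0.05 log units; within the scatter) is therefore none beyond the scatter. Compound 3 is estimated to give 33000 nM in this assay, with a plausible range from 11000 nM to 100000 nM.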

Compound 3, half-maximal inhibitory concentration: 1800 nM
Compound 3: the middle estimate sits 18-fold (1.26 log units) above what was measured; the whole stated range lies above it.
By their numbers in this assay, from the lowest: compound 3; then compounds 1 and 2 (each within the scatter of the next).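

In this assay, methyl in place of carboxy on this aromatic carbon gives a 21-fold lower number from compound 2 to compound 3 (1.31 log units; beyond the scatter) and shows that the substituent on this ring can matter a great deal, which the flat pair of compound 1 and compound 2 had hidden. The change of the whole aryl group, 3-methylphenyl in place of 2-nitrophenyl, gives a 21-fold lower number from compound 1 to compound 3 (1.31 log units; beyond the scatter), so compound 3 stands clear of both earlier compounds, and a single flat step proved a poor guide to the rest of this position. Nothing available explains why the methyl compound differs so strongly from the other two.

The compounds shown leave open whether the gain depends on methyl itself or would also appear with an unsubstituted phenyl ring, or with ethyl, methoxy, chlorine or an amine on the same aromatic carbon. They also leave open whether a larger alkyl group there would take the number lower still or lose the gain, since one methyl compound marks only a single point on that scale.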